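The compounds below may be only part of what the source reports. "The series", "measured", "known", "first", "only" and "open" are said of these compounds alone.

Measured in an ADME assay on cells (Macrophage, Mus musculus) for cytotoxicity, read by resazurin assay, with a stated time of 3 days; a lower number here means a stronger inhibitor, a higher number a weaker inhibitor:
- compound 1 `O=C(Nc1cccc(C(F)(F)F)c1)c1cc(Cl)ccc1O`: 5900 nM
- compound 2 `O=C(Nc1ccc(C(F)(F)F)c(C(F)(F)F)c1)c1cc(Cl)ccc1O`: 4900 nM
- compound 3 `O=C(Nc1cc(C(F)(F)F)ccc1C(F)(F)F)c1cc(Cl)ccc1O`: 6600 nM

Compound 1 is not separated from the other two numbers, as both steps away from it stay within the scatter: a 1.2-fold lower number from compound 1 to compound 2 (0.08 log units; within the scatter) and a 1.1-fold higher number from compound 1 to compound 3 (0.05 log units; within the scatter).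

Next in line is compound 4 `O=C(Nc1cccc(F)c1)c1cc(Cl)ccc1O`, which differs from compound 1 as follows: fluoro in place of trifluoromethyl on an aromatic carbon. In words, this is fluoro in place of trifluoromethyl on an aromatic carbon.

Neither measured step is this same change. Among the compounds with values here, both put trifluoromethyl in place of hydrogen on an aromatic carbon, and the series so far holds no measured fluoro compound, so they bear on compound 4 only indirectly. They do show that this assay has not moved beyond the scatter with either change to the trifluoromethyl substitution, so no step beyond the scatter is expected here.

The expected value for compound 4 is 7000 nM, with an estimated range of 3000 nM to 15000 nM. The estimate amounts to a 1.2-fold higher number from compound 1 to compound 4 (0.07 log units; within the scatter).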

Compound 4, half-maximal inhibitory concentration: 15000 nM
Estimate against measurement, compound 4: 2.1-fold (0.33 log units) below; the range from low to high includes it.
By their numbers in this assay, from the lowest: compounds 2, 1 and 3 (each within the scatter of the next); then compound 4.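

In this assay, within the data shown here, the exchange of trifluoromethyl for fluoro gives a 2.5-fold higher number from compound 1 to compound 4 (0.41 log units; beyond the scatter), the first step to lie beyond the scatter, though a modest one. The earlier steps shown here only added a second trifluoromethyl while keeping the first, whereas this one replaces the group on an aromatic carbon meta to a large group and shows that the number at this place can respond to the group it carries. No measurement shown gives a reason for this step.

From the compounds shown here alone, whether a nitrile or a methoxy group at this place would stay close to compound 1 or move toward compound 4 remains open. A single exchange also leaves open whether fluoro in place of trifluoromethyl would give a similar step on other versions of the shared core.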